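The source may hold more compounds than are shown below. What is called first, only, known or untested is meant among the compounds shown, and "the series" means these compounds.

Of the compounds shown here, three have been measured in a functional assay, read by spectrophotometry, with a stated time of 3 min; on this read-out higher numbers stand for weaker inhibition and lower numbers for stronger inhibition. Compound 1, `Cc1ccc2[nH]c(=O)c(/C=N/c3ccccc3O)cc2c1`, gives 8240 nM. Compound 2, `Cc1ccc2[nH]c(=O)c(/C=N/Nc3ccc([N+](=O)[O-])cc3)cc2c1`, gives 8250 nM. Compound 3, `NS(=O)(=O)CC(=O)N/N=C/c1cc2ccccc2[nH]c1=O`, gives 8910 nM. Compound 2 thus sits with the second highest of the three numbers, yet its gaps to compound 1 and to compound 3 both lie within the usual scatter of this assay, so the three results cannot be told apart from one another.

The compound not yet measured is compound 4, `Cc1ccc2[nH]c(=O)c(/C=N/Nc3ccc([N+](=O)[O-])cc3[N+](=O)[O-])cc2c1`. It differs from compound 2 in a single place: nitro in place of hydrogen on an aromatic carbon. Within the data shown here, no pair of measured compounds that differ in only one place exists here, so nothing measured shows how a change of this kind plays out in this assay. Among the measured compounds shown here, the only guide is that every compound measured so far, whatever group hangs from the shared core, returned a number within the scatter of the others.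

On that basis the expected step, a 1.0-fold lower number from compound 2 to compound 4 (0.01 log units; within the scatter), is none beyond the scatter, in no particular direction. Compound 4 is therefore estimated at 8000 nM, with a plausible range from 3000 nM to 20000 nM.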

Compound 4, half-maximal inhibitory concentration: 144000 nM
For compound 4 the middle estimate is 18-fold (1.26 log units) below the measured one, and the stated range ends below it.
By their numbers in this assay, from the lowest: compounds 1, 2 and 3 (each within the scatter of the next); then compound 4.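

In this assay putting a nitro group in place of hydrogen on this aromatic carbon, ortho to a large group and meta to a nitro group, gives a 17-fold higher number from compound 2 to compound 4 (1.24 log units; beyond the scatter) and so clearly weakens inhibition. This is the first sign in the compounds shown that a single change can shift the read-out beyond the usual scatter, and it shows that this position does not accept every group without consequence. No accompanying measurement bears on this result, and the reason for the weaker inhibition remains unknown.

The compounds shown leave open whether this weakening belongs to the nitro group itself or would follow from any group on this carbon, a question that a methyl group, a chlorine atom or an amine in the same place could help to answer. They also leave open whether a nitro group on this carbon would have a similar effect in a compound without the existing nitro group, for example one with a methoxy group in its place.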